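The source may report more compounds than this note shows. Statements on the series, on what has been measured and on what is new or still open speak of the compounds shown alone.

Measured compounds in a functional assay on HeLa cells (Homo sapiens) for cytotoxicity, read by MTT assay, with a stated time of 72 h, tested at 3 uM; on this read-out higher numbers stand for more inhibition of growth at the one concentration tested and lower numbers for less inhibition of growth:
compound 1 `N/C(=N\NC(=S)N1CCCC1)c1ccc(F)cn1`, 77.7%
compound 2 `N/C(=N\NC(=S)N1CCCCC1)c1ccccn1`, 49.2%
compound 3 `Cc1cccc(/C(N)=N/NC(=S)N2CCCCC2)n1`, 68.9%

Among these three, compound 1 gives the highest number, and its nearest neighbour is compound 3, whose value lies within the usual scatter of it, while compound 2 lies beyond the scatter below it. For the measured compounds named here, the one step between measured compounds that differ in a single place runs a number 19.7 percentage points higher from compound 2 to compound 3 (beyond the scatter), a methyl in place of a hydrogen on an aromatic carbon. Compound 1 and compound 2 differ in two places at once, so their values can only be set side by side, not read as a single step.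

Compound 4 `N/C(=N\NC(=S)N1CCOCC1)c1ccc(F)cn1` has not yet been measured. It departs from compound 1 by morpholin-4-yl in place of pyrrolidin-1-yl on a thiocarbonyl carbon. Going by the values given here, no measured step touches this part of the molecule: the only known step concerns the aromatic ring, not the ring on the thiocarbonyl carbon, so it gives no guide to the direction or size of this change. With nothing to lean on, the expectation for compound 4 in this assay is a value somewhat below that of compound 1, but with a wide range, estimated at 65% (range 40% to 85%). This estimate means an expected step of a number 12.7 percentage points lower from compound 1 to compound 4 (beyond the scatter).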

Compound 4, percent growth inhibition at one concentration: 59.7%
Compound 4: the middle estimate sits 5.3 percentage points above what was measured, and the stated range covers the measured number.
By their numbers in this assay, from the lowest: compound 2; then compounds 4, 3 and 1 (each within the scatter of the next, the first and the last beyond it).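

For the compounds shown here, until now the only measured step concerned the aromatic ring, so this is the first direct look at the ring on the thiocarbonyl carbon. In this assay, morpholin-4-yl in place of pyrrolidin-1-yl gives a number 18 percentage points lower from compound 1 to compound 4 (beyond the scatter), which shows that the number responds to a change at this place as well as to one on the aromatic ring. The swap alters the ring size and brings in an oxygen, a hydrogen-bond acceptor, all in one step, and nothing available here explains the lower number.

The compounds shown do not separate the larger ring from the added oxygen, since no single step changes one without the other. A dimethylamino group or a 4-methylpiperazin-1-yl group on the thiocarbonyl carbon of the core of compound 1 would show whether an open chain or a second ring nitrogen is tolerated in this place, and whether the number then stays close to that of compound 1 or falls as it does with morpholin-4-yl.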